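Replacing a pyridinyl arm with a thiophenyl arm

The source may report more compounds than this note shows. Statements on the series, on what has been measured and on what is new or still open speak of the compounds shown alone.

Measured compounds:
compound 1 `Oc1ccc(-c2cc(-c3ccccn3)nc(-c3ccccc3Cl)c2)cc1` — "not determined" (no result reported)
compound 2 `Oc1ccc(-c2cc(-c3cccc(Cl)c3)nc(-c3ccccn3)c2)cc1` — 25400 nM

In an ADME assay on HEK293 cells (Homo sapiens) for cytotoxicity, read by CCK-8 assay and cell counting, with a stated time of 2 days (a lower number here means a stronger inhibitor, a higher number a weaker inhibitor), compound 1 gives "not determined" (no result reported); no result is reported for it. Compound 2 gives 25400 nM in this assay. Compound 3 `Oc1ccc(-c2cc(-c3ccsc3)nc(-c3ccccc3Cl)c2)cc1` differs from compound 1 by thiophen-3-yl in place of pyridin-2-yl on an aromatic carbon. Among the compounds with values here, with no step between measured compounds available, the size of the step in this assay cannot be read from the data; compound 3 is expected to fall near the value of compound 2, with any shift likely within the usual scatter. The estimate for compound 3 is 25000 nM, in the range 8000 nM to 80000 nM.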

Compound 3, half-maximal inhibitory concentration: 5930 nM
Beside the measured number, compound 3's estimate is 4.2-fold (0.62 log units) above it; the whole stated range lies above it.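

In this assay, within the data shown here, compound 1 gives "not determined" (no result reported) and so no step to compound 3 can be read. The compounds shown leave open what replacing pyridin-2-yl with thiophen-3-yl does to this read-out. No evidence bears on the result.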